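From compound 2 to compound 3 in a reporter assay

The compounds below may be only part of what the source reports. "The series", "measured", "known", "first", "only" and "open" are said of these compounds alone.

In a functional assay on Shh Light II cells (Mus musculus) for inhibition, read by a luciferase reporter (a higher number here means a weaker inhibitor, a lower number a stronger inhibitor), two compounds have been measured so far. Compound 1 (`COc1ccccc1NC(=O)N1CCC(c2noc(-c3ccc4ccccc4n3)n2)CC1`) reads 2400 nM there, while compound 2 (`O=C(NC1CC[S+]([O-])CC1)N1CCC(c2nc(-c3ccc4ccccc4n3)no2)CC1`) reads 850 nM and so holds the lower of the two numbers, a gap beyond the usual scatter. Compound 3 (`COc1ccccc1NC(=O)N1CCC(c2nc(-c3ccc4ccccc4n3)no2)CC1`) keeps the core of compound 2 and alters one group on an amide-type nitrogen, with a group of 8 heavy atoms (7 carbon, 1 oxygen; one six-membered aromatic ring of carbon only) in place of a group of 7 heavy atoms (5 carbon, 1 oxygen, 1 sulfur; one six-membered non-aromatic ring with 1 hetero atom), on an amide-type nitrogen as the whole of the difference. Among the compounds with values here, no measured step isolates this change, so the expectation rests on two values alone. Compound 1 at 2400 nM carries the same 2-methoxyphenyl group, and compound 2 at 850 nM carries the group that leaves. Compound 3 is therefore expected to land near compound 2 or somewhat above it in this assay and no step beyond the scatter is the likeliest outcome. The change is estimated as a 1.4-fold higher number from compound 2 to compound 3 (0.15 log units; within the scatter) and would point toward weaker inhibition. In this assay compound 3 is expected at 1200 nM within an estimated range of 300 nM to 4500 nM for now.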

Compound 3, half-maximal inhibitory concentration: 410 nM
For compound 3 the middle estimate is 2.9-fold (0.47 log units) above the measured one, and the stated range covers the measured number.
By their numbers in this assay, from the lowest: compound 3; then compound 2; then compound 1.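

On the amide-type nitrogen, 2-methoxyphenyl in place of the sulfur-bearing non-aromatic ring gives a 2.1-fold lower number from compound 2 to compound 3 (0.32 log units; beyond the scatter) in this assay, the first sign that this position responds to a change of group. The step is modest, but it lies beyond the scatter, and it shows that the ring with its hetero atom is not needed at this place for the lower number. The result also shows that 2-methoxyphenyl alone does not set the reading: compound 1 carries the same group and gives 2400 nM, whereas compound 3, with a different arrangement of the core, gives 410 nM. Nothing at hand explains why the number falls with this change.

The compounds shown leave open how a plain phenyl, a cyclohexyl ring without sulfur or a group bearing a carboxylic acid would read on this amide-type nitrogen, and so whether the methoxy group of 2-methoxyphenyl contributes at all. They also leave open whether the same exchange would give a step of similar size on the core of compound 1.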